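The compounds below may be only part of what the source reports. "The series", "measured", "known", "first", "only" and "open" are said of these compounds alone.

Three acids of one series have been read in an assay on CHO cells for displacement of a labelled ligand from prostaglandin D2 receptor 2 (Homo sapiens), read by scintillation counting; a higher number here means a weaker inhibitor, a lower number a stronger inhibitor. Compound 1 `Cc1ccc(S(=O)(=O)N2CCN(C)CC2)cc1C#Cc1cc(Cl)ccc1OCC(=O)O` gives 21 nM, compound 2 `COCCNS(=O)(=O)c1ccc(C)c(C#Cc2cc(Cl)ccc2OCC(=O)O)c1` gives 3.6 nM, and compound 3 `CNS(=O)(=O)c1ccc(C)c(C#Cc2cc(Cl)ccc2OCC(=O)O)c1` gives 10 nM. Compound 3 thus holds the second highest of the three numbers: the nearest is compound 1, with a 2.1-fold lower number from compound 1 to compound 3 (0.32 log units; beyond the scatter), the furthest compound 2, with a 2.8-fold higher number from compound 2 to compound 3 (0.44 log units; beyond the scatter). Every change so far sits on the sulfonyl sulfur or on the sulfonamide nitrogen, and every step has stayed modest; a 5.8-fold lower number from compound 1 to compound 2 (0.77 log units; beyond the scatter) is the largest among them.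

Compound 4 `CCN(CC)S(=O)(=O)c1ccc(C)c(C#Cc2cc(Cl)ccc2OCC(=O)O)c1` is not yet measured. It differs from compound 3 by diethylamino in place of methylamino on a sulfonyl sulfur. For the measured compounds named here, no measured pair shows this exact exchange. Going by the values given here, the steps that bear on it are a 2.1-fold lower number from compound 1 to compound 3 (0.32 log units; beyond the scatter), where a group with no hydrogen-bond donor gave way to methylamino and the number fell, and a 2.8-fold higher number from compound 2 to compound 3 (0.44 log units; beyond the scatter), where a chain on the sulfonamide nitrogen was taken away and the number rose. The two pull in opposite directions and both were modest, so for compound 4 a shift of the order a 1.5-fold higher number from compound 3 to compound 4 (0.18 log units; within the scatter) in this assay is expected, most likely not beyond the scatter. The estimate for compound 4 is 15 nM, with a range from 5 nM to 45 nM.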

Compound 4, inhibition constant: 3.4 nM
For compound 4 the middle estimate is 4.4-fold (0.64 log units) above the measured one; measured number below the stated range.
By their numbers in this assay, from the lowest: compounds 4 and 2 (each within the scatter of the next); then compound 3; then compound 1.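

In this assay, a 2.9-fold lower number from compound 3 to compound 4 (0.47 log units; beyond the scatter) shows that at this position on the sulfonyl sulfur, diethylamino, with no hydrogen-bond donor, gives a lower number than methylamino, so the hydrogen on the sulfonamide nitrogen is not required for a low number in this small set. The lack of a donor does not settle the value by itself, since 4-methylpiperazin-1-yl also has none and a 6.2-fold lower number from compound 1 to compound 4 (0.79 log units; beyond the scatter) separates it from diethylamino, while a 1.1-fold lower number from compound 2 to compound 4 (0.02 log units; within the scatter) puts diethylamino level with (2-methoxyethyl)amino, which keeps that hydrogen. No supporting data on hand explain why these groups rank as they do.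

The compounds shown leave open whether the trend continues with a longer chain such as dipropylamino or with a ring lacking the second nitrogen, such as pyrrolidin-1-yl or morpholin-4-yl, which would help show whether the ring or its methylated amine goes with the higher number of compound 1. On these data alone, a plain unsubstituted amino group on the sulfonyl sulfur also remains open, as does whether these differences hold with another group in place of the chloro substituent on the shared core.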